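The source may hold more compounds than are shown below. What is called first, only, known or untested is meant among the compounds shown, and "the series" means these compounds.

Measured compounds in a functional assay on KB cells (Homo sapiens) for cytotoxicity, read by MTT assay, with a stated time of 72 h; a higher number here means that more compound is needed for the effect, a lower number that less compound is needed:
- compound 1 `O=C1/C(=C\c2cc3ccccc3nc2Cl)c2ccccc2N1c1c(Cl)cccc1Cl`: 10 ug/mL
- compound 2 `O=C1/C(=C\c2cccc(Oc3ccccc3)c2)c2ccccc2N1c1c(Cl)cccc1Cl`: 5 ug/mL
- compound 3 `CN(C)c1ccc(/C=C2\C(=O)N(c3c(Cl)cccc3Cl)c3ccccc32)cc1`: 15 ug/mL

All three share one core and differ only in the aromatic group hanging from its exocyclic double bond. On the numbers shown, compound 3 has the highest figure of the three, meaning the most compound is needed in this assay. Its gap to compound 1 lies within the usual scatter, so these two cannot be told apart; its gap to compound 2 is beyond the scatter, so compound 2 genuinely needs less compound.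

Compound 4 `O=C1/C(=C\c2ccc(Cl)cc2)c2ccccc2N1c1c(Cl)cccc1Cl` has not been measured. It differs from compound 3 by one change: chloro in place of dimethylamino on an aromatic carbon. Among the measured compounds shown here, no directly comparable pair among the measured compounds shows what this swap does, so any expectation rests on the spread of the three values alone. The expected step from compound 3 to compound 4 is a 1.9-fold lower number from compound 3 to compound 4 (0.27 log units; within the scatter) in this assay, a modest move toward a lower number, not clearly beyond the scatter. Compound 4 is therefore estimated at 8 ug/mL, with a likely range from 3 ug/mL to 25 ug/mL.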

Compound 4, concentration for half-maximal effect: 2 ug/mL
For compound 4 the middle estimate is 4.0-fold (0.60 log units) above the measured one; the whole stated range lies above it.
By their numbers in this assay, from the lowest: compound 4; then compounds 2, 1 and 3 (each within the scatter of the next, the first and the last beyond it).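

The change from 4-(dimethylamino)phenyl to 4-chlorophenyl gives a 7.5-fold lower number from compound 3 to compound 4 (0.88 log units; beyond the scatter) in this assay. Among the compounds shown here, this is the first comparison here between two compounds that differ in one place, and it shows that the group on this aromatic carbon can shift the result by more than the usual scatter, which the spread of the earlier values alone could not show. Nothing available here explains why this swap produces a step of this size.

For the compounds shown here, the single step cannot separate the effect of removing dimethylamino from that of adding chloro. As far as these compounds go, it remains open how a plain hydrogen, a fluoro or a methoxy on this same carbon would compare, and whether any of them would fall near compound 3 or near compound 4.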